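A few compounds are considered here, and "the series" means these few. Any claim that something is new, unique, unknown or untested is made for them only; others in the source may bear on it.

Three compounds have been measured in a functional assay on HeLa cells (Homo sapiens) for cytotoxicity, read by MTT assay, with a stated time of 24 h; on this read-out lower numbers stand for stronger inhibition and higher numbers for weaker inhibition:

Compound 1 `COc1cc(/C=C2\CN(C)C/C(=C\c3ccccc3F)C2=O)cc(OC)c1` gives 5450 nM.
Compound 2 `CN1C/C(=C\c2ccc(C#N)cc2)C(=O)/C(=C/c2ccccc2F)C1` gives 1340 nM.
Compound 3 `COc1cc(/C=C2\CN(C)C/C(=C\c3ccc(F)cc3)C2=O)cc(OC)c1` gives 10200 nM.

Compound 2 has the lowest number of the three, and its gaps to compound 1 and compound 3 are both beyond the usual scatter. Compound 1 and compound 2 share only part of their structure; how their two cores differ is not broken down here.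

Compound 3 is made from compound 1 by one change (4-fluorophenyl in place of 2-fluorophenyl on a double-bonded chain carbon bound to a double-bonded ring carbon). This gave a 1.9-fold higher number from compound 1 to compound 3 (0.27 log units; within the scatter), so the two numbers cannot be told apart.

Compound 4 `CN1C/C(=C\c2ccc(F)cc2)C(=O)/C(=C/c2ccc(C#N)cc2)C1` has not been measured. It is made from compound 2 by the same change (4-fluorophenyl in place of 2-fluorophenyl on a double-bonded chain carbon bound to a double-bonded ring carbon), at the same place. Since the only earlier case of this change moved the number little, compound 4 is expected to sit close to compound 2, with a step of about a 1.9-fold higher number from compound 2 to compound 4 (0.27 log units; within the scatter) in this assay, resting on the step from compound 1 to compound 3. The expected value for compound 4 is 2500 nM, estimated to fall between 1000 nM and 6500 nM.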

Compound 4, half-maximal inhibitory concentration: 10200 nM
Estimate against measurement, compound 4: 4.1-fold (0.61 log units) below; measured number above the stated range.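

In this assay, putting the 4-fluorophenyl group in place of the 2-fluorophenyl group on the core of compound 2 gave a 7.6-fold higher number from compound 2 to compound 4 (0.88 log units; beyond the scatter), so on this core the change has a clear effect. Set beside the earlier case, the same change does not carry over with the same size from one core to the other: the same change on two cores in this assay, a 1.9-fold higher number (0.27 log units; within the scatter) from compound 1 to compound 3 and a 7.6-fold higher number (0.88 log units; beyond the scatter) from compound 2 to compound 4, 4.1-fold (0.61 log units) apart, beyond the scatter of two such steps. In this series, then, a step measured on one core is a poor guide to the step on the other, but two pairs cannot show why the steps differ or what would happen on any further core.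

Among the compounds shown here, both pairs involve only this one swap between fluorophenyl groups, so it remains open how a different group in that place, such as a chlorophenyl or an aminophenyl group, would behave on each core. Going by these compounds, it also remains open whether a third core, carrying for instance a carboxylic acid on its other phenyl ring, would follow the smaller step or the larger one.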